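Cytotoxicity notes on the aryl ether swap in compound 3

The source may hold more compounds than are shown below. What is called first, only, known or untested is meant among the compounds shown, and "the series" means these compounds.

compound 1 `O=C(Nc1ncc(Cc2ccc(F)cc2)s1)c1ccc(Br)cc1`: > 50000 nM
compound 2 `O=C(Nc1ncc(Cc2ccc(Cl)cc2)s1)c1ccc(F)cc1F`: "not toxic" (no number reported)
compound 3 `CC(C)(C)OC(=O)Nc1ncc(C(Oc2ccc(Br)cc2)c2ccc(Cl)cc2)s1`: > 50000 nM

All three were run in an ADME assay on HepG2 2.2.15 cells (Homo sapiens) for cytotoxicity; a lower number here means that less compound is tolerated, a higher number that more compound is tolerated. For compound 1 the entry is a limit of the assay, > 50000 nM. Compound 2 is recorded as "not toxic" (no number reported), with no number given. For compound 3 the entry is again only a limit, > 50000 nM. Compound 3 therefore stands where compound 1 stands, at the limit of > 50000 nM in this assay, at which 2 of the 3 values shown sit; no order among the three compounds can be drawn, and nothing here is beyond the scatter.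

Compound 4 `CC(C)(C)OC(=O)Nc1ncc(C(Oc2cccc(C#N)c2)c2ccc(Cl)cc2)s1` differs from compound 3 in one place: 3-cyanophenyl in place of 4-bromophenyl on an oxygen on a saturated carbon. For the measured compounds named here, no two measured compounds differ in a single place, so no measured step exists to guide the expectation. With two of three entries at the limit of > 50000 nM in this assay, at which 2 of the 3 values shown sit, and the third recorded without toxicity, the expected step from compound 3 to compound 4 in this assay is none beyond the scatter, a number no higher from compound 3 to compound 4 (the limit leaves the size open). Compound 4 is expected at 50000 nM, in the range 20000 nM to 100000 nM, most likely reported again only as a limit.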

Compound 4, half-maximal cytotoxic concentration: > 50000 nM
Compound 4 was reported as a limit; the forecaster's own chance of this, stated with the estimate: 70%; the middle value lies on the limit itself.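

Compound 3 and compound 4 are both recorded only as limits in this assay, so no step between them can be read: the limit of > 50000 nM in this assay, at which 3 of the 4 values shown sit.

The compounds shown leave open at what concentration cytotoxicity would appear for any of them, and whether 3-cyanophenyl and 4-bromophenyl differ at all in this read-out.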